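Butoxy to isobutyl on the aromatic carbon

The source may report more compounds than this note shows. Statements on the series, on what has been measured and on what is new or still open speak of the compounds shown alone.

Among the compounds with values here, compound 3 `CCCCOc1ccc(NS(=O)(=O)c2ccc(N3CCNC3=O)cc2)cc1` gives 580 nM in a functional assay on M21 cells (Homo sapiens) for antiproliferative activity, read by sulforhodamine B assay, with a stated time of 48 h (on this read-out lower numbers stand for stronger inhibition and higher numbers for weaker inhibition), the highest of the three numbers so far, though all three sit within the scatter of one another: compound 1 `CCc1ccc(NS(=O)(=O)c2ccc(N3CCNC3=O)cc2)cc1` gives 480 nM and compound 2 `O=C1NCCN1c1ccc(S(=O)(=O)Nc2ccc(OC(F)F)cc2)cc1` gives 410 nM. Compound 4 `CC(C)Cc1ccc(NS(=O)(=O)c2ccc(N3CCNC3=O)cc2)cc1` carries isobutyl in place of butoxy on an aromatic carbon. The step most like it is the chain exchange at the same carbon, a 1.2-fold higher number from compound 1 to compound 3 (0.08 log units; within the scatter), and the other change at that carbon, a 1.2-fold lower number from compound 1 to compound 2 (0.07 log units; within the scatter), was equally flat; the remaining step, a 1.4-fold higher number from compound 2 to compound 3 (0.15 log units; within the scatter), also stayed inside the scatter. Compound 4 is therefore expected to show no step beyond the scatter, a 1.2-fold lower number from compound 3 to compound 4 (0.06 log units; within the scatter). The estimate for compound 4 is 500 nM, with a range of 250 nM to 1000 nM.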

Compound 4, half-maximal inhibitory concentration: > 1000 nM
Compound 4: a limit, no number; the forecaster's own chance of this, stated with the estimate: 3%; at least 2.0-fold (0.30 log units) between middle value and limit.
By their numbers in this assay, from the lowest: compounds 2, 1 and 3 (each within the scatter of the next). At a limit, above all of these: compound 4.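

In this assay the reading for compound 4 is a limit of the assay, not a number: the limit of > 1000 nM in this assay, at which 1 of the 4 values shown sits. Isobutyl is the first group at this aromatic carbon to give steps beyond the scatter, an at least 2.0-fold higher number from compound 1 to compound 4 (0.31 log units; beyond the scatter) and an at least 2.4-fold higher number from compound 2 to compound 4 (0.38 log units; beyond the scatter), so this position is not indifferent to every chain placed on it. Against butoxy only a floor can be read, an at least 1.7-fold higher number from compound 3 to compound 4 (0.23 log units; that floor lies within the scatter).

Going by these compounds, how far compound 4 lies past its limit remains open. On these data alone, whether the branching or the absent oxygen counts more also remains open; a straight butyl chain or an isobutoxy group at this carbon would separate the two.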